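A few compounds are considered here, and "the series" means these few. Any claim that something is new, unique, unknown or untested is made for them only; others in the source may bear on it.

Of the compounds shown here, three have been tested so far in a functional assay on MCF7 cells (Homo sapiens) for cytotoxicity, read by MTT assay; a lower number here means a stronger inhibitor, a higher number a weaker inhibitor. Compound 1 `COc1ccc2c(c1)CCC/C2=N\NCc1nc2ccccc2[nH]1` gives 63000 nM in this assay. Compound 2 `CC1=NN(Cc2nc3ccccc3[nH]2)C(=O)C1` gives 62000 nM, the lowest number of the three, although its gap to compound 1 lies within the usual scatter, so the two cannot be told apart. Compound 3 `O=[N+]([O-])c1ccc2[nH]c(CNc3nc(-c4ccccc4)cs3)nc2c1` gives 254000 nM, a number beyond the scatter from compound 2, and compound 3 is built around a different core from the other two, so its weaker result cannot be traced to any single part of its structure.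

The next compound, compound 4 `CC1=NN(Cc2nc3cc([N+](=O)[O-])ccc3[nH]2)C(=O)C1`, keeps the whole of compound 2 and adds one group: nitro in place of hydrogen on an aromatic carbon. Going by the values given here, no measured pair here isolates this change on the shared core of compound 2, so there is nothing to copy from. Compound 3 also carries a nitro group and is the weakest of the set, but it differs from compound 2 in many places at once, which leaves no clean lesson.

On that basis the step from compound 2 to compound 4 is expected to be small in this assay, a 1.1-fold higher number from compound 2 to compound 4 (0.05 log units; within the scatter), with no clear direction beyond the scatter. Compound 4 is estimated to give 70000 nM in this assay, within a range of 25000 nM to 200000 nM.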

Compound 4, half-maximal inhibitory concentration: 281000 nM
Compound 4: the middle estimate sits 4.0-fold (0.60 log units) below what was measured, and the stated range ends below it.
By their numbers in this assay, from the lowest: compounds 2 and 1 (each within the scatter of the next); then compounds 3 and 4 (each within the scatter of the next).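

In this assay, putting nitro in place of hydrogen on an aromatic carbon of the six-membered ring of carbon only gives a 4.5-fold higher number from compound 2 to compound 4 (0.66 log units; beyond the scatter) and so moves the result beyond the usual scatter, towards a weaker inhibitor. Going by these compounds alone, this is the first pair in the set that differs in one place, so the rise in the number can be tied to this single change on the shared core of compound 2, and not to a mixture of differences. Nothing given here explains how the nitro group produces this rise, so the step stands as an observation without a known cause.

Nitro is the only group shown at this aromatic carbon, so it remains open whether an amine or a chlorine atom there would also raise the number, or whether the rise is specific to nitro. A single pair also leaves open whether nitro would produce a step of similar size at another carbon of that ring, or on the core of compound 1.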